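The source may report more compounds than this note shows. Statements on the series, on what has been measured and on what is new or still open speak of the compounds shown alone.

Measured so far:
Compound 1, `COC(=O)c1nc(C)c2c(c1N)C(=O)N(Cc1ccccc1)C2=O`: 7400 nM
Compound 2, `CCCOC(=O)c1nc(C)c2c(c1N)C(=O)N(Cc1ccccc1)C2=O`: < 5000 nM
Compound 3, `CNC(=O)c1nc(C)c2c(c1N)C(=O)N(Cc1ccccc1)C2=O`: 41000 nM

In a physicochemical assay for solubility, using the shake flask method, in simulated intestinal fluid, measured as kinetic solubility, with a stated time of 2 h, at 25 degrees C, at pH 6.5 (a lower number here means a less soluble compound, a higher number a more soluble compound), compound 2 stands at a limit of the assay, (the limit of < 5000 nM in this assay, at which 1 of the 3 values shown sits), so its true number is not known. Compound 1 and compound 3 give numbers, and the steps that reach compound 2 or leave it run in one direction: an at least 1.4-fold lower number from compound 1 to compound 2 (0.17 log units; that floor lies within the scatter); an at least 8.2-fold higher number from compound 2 to compound 3 (0.91 log units; beyond the scatter); also a 5.5-fold higher number from compound 1 to compound 3 (0.74 log units; beyond the scatter). Compound 4, `Cc1nnc(-c2nc(C)c3c(c2N)C(=O)N(Cc2ccccc2)C3=O)o1`, is not yet measured. It differs from compound 2 in one place: 5-methyl-1,3,4-oxadiazol-2-yl in place of propoxycarbonyl on an aromatic carbon. Going by the values given here, no measured step swaps an ester for an aromatic ring, so the size of the step in this assay is guessed from the fact that the propoxycarbonyl leaves and a 5-methyl-1,3,4-oxadiazol-2-yl enters. For compound 4 the expected step is an at least 1.6-fold higher number from compound 2 to compound 4 (0.20 log units; that floor lies within the scatter), upward, though compound 2 being at a limit makes this rough. Compound 4 is estimated at 8000 nM, in a range from 2500 nM to 25000 nM.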

Compound 4, solubility: < 5000 nM
Compound 4: a limit, no number (the forecaster's own chance of this, stated with the estimate: 30%); middle value at least 1.6-fold (0.20 log units) away from the limit.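

In this assay, compound 4 gives < 5000 nM, which is a limit and not a number. This shows that, on this aromatic carbon, a 5-methyl-1,3,4-oxadiazol-2-yl does not keep the high number seen with methylcarbamoyl, with an at least 8.2-fold lower number from compound 3 to compound 4 (0.91 log units; beyond the scatter), while replacing the methoxycarbonyl gives only a small floor that cannot establish a real drop, with an at least 1.4-fold lower number from compound 1 to compound 4 (0.17 log units; that floor lies within the scatter). The step between compound 2 and compound 4 cannot be read, since both sit at the same limit: the limit of < 5000 nM in this assay, at which 2 of the 4 values shown sit.

On these data alone, the true numbers of compound 2 and compound 4 remain unknown, so these two groups cannot be ranked against each other. Also open, as far as these compounds go, is whether a carboxylic acid or a longer amide such as ethylcarbamoyl on this aromatic carbon would stay close to compound 3.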